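Basic Side Chain Replaces the Methoxyphenyl Urea Cap

The compounds below may be only part of what the source reports. "The series", "measured", "known", "first", "only" and "open" are said of these compounds alone.

Three ureas share one core. Compound 1 `CN(C)Cc1ccc(NC(=O)Nc2ccc3ncnc(Nc4cccc(C(F)(F)F)c4)c3c2)cc1` gives 1030 nM in a functional assay on A-431 cells (Homo sapiens) for antiproliferative activity, read by MTT assay, with a stated time of 72 h; a higher number here means a weaker inhibitor, a lower number a stronger inhibitor. Compound 2 `Cc1ccc(NC(=O)Nc2ccc3ncnc(Nc4cccc(C(F)(F)F)c4)c3c2)cc1` gives only a limit of the assay, > 10000 nM. Compound 3 `COc1ccc(NC(=O)Nc2ccc3ncnc(Nc4cccc(C(F)(F)F)c4)c3c2)cc1` gives 4950 nM. Compound 3 stands at the highest of the two numbers given; the nearest step, a 4.8-fold higher number from compound 1 to compound 3 (0.68 log units; beyond the scatter), lies beyond the scatter, while an at least 2.0-fold lower number from compound 2 to compound 3 (0.30 log units; that floor lies within the scatter) rests on a limit, (the limit of > 10000 nM in this assay, at which 1 of the 3 values shown sits). Compound 4 `CN1CCN(CCNC(=O)Nc2ccc3ncnc(Nc4cccc(C(F)(F)F)c4)c3c2)CC1` differs from compound 3 by 2-(4-methylpiperazin-1-yl)ethyl in place of 4-methoxyphenyl on an amide-type nitrogen. The step of a 4.8-fold higher number from compound 1 to compound 3 (0.68 log units; beyond the scatter) bears on this: exchanging the (dimethylamino)methyl for a methoxy raised the number, and compound 4 restores an amine within the 2-(4-methylpiperazin-1-yl)ethyl group, now on a chain rather than an aryl. Compound 4 is therefore expected to show a lower number, a 2.5-fold lower number from compound 3 to compound 4 (0.39 log units; beyond the scatter). Compound 4 is estimated at 2000 nM, between 400 nM and 10000 nM.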

Compound 4, half-maximal inhibitory concentration: > 10000 nM
Compound 4 ended at the assay's limit; the forecaster's own chance of this, stated with the estimate: 15%; at least 5.0-fold (0.69 log units) between middle value and limit.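

An amine is not enough on its own at this nitrogen: compound 4 carries one in its 2-(4-methylpiperazin-1-yl)ethyl chain, yet replacing the 4-((dimethylamino)methyl)phenyl gives an at least 9.7-fold higher number from compound 1 to compound 4 (0.98 log units; beyond the scatter). Against the 4-methoxyphenyl, the change reads an at least 2.0-fold higher number from compound 3 to compound 4 (0.30 log units; that floor lies within the scatter), so no loss beyond the scatter can be claimed. The value of compound 4 is a limit, shared with compound 2, and the step between them cannot be read: the limit of > 10000 nM in this assay, at which 2 of the 4 values shown sit.

Open, from the compounds shown here alone, is whether a 4-((4-methylpiperazin-1-yl)methyl)phenyl group on the amide-type nitrogen would match compound 1. Also open, going by these compounds, is whether the aromatic ring or the amine's placement matters more.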